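A few compounds are considered here, and "the series" means these few. Any claim that something is new, unique, unknown or untested is made for them only; others in the source may bear on it.

Values so far in a functional assay on A549 cells (Homo sapiens) for antiproliferative activity, read by MTT assay, with a stated time of 24 h (on this read-out higher numbers stand for weaker inhibition and lower numbers for stronger inhibition), are these
compound 1 `Cc1ccc(-c2nn(-c3ccccc3)cc2-c2nc3ccccc3n2S(=O)(=O)c2cc(C)ccc2C)cc1` gives 270 nM
compound 2 `Cc1ccc(-c2nn(-c3ccccc3)cc2-c2nc3ccccc3n2S(=O)(=O)c2ccc(Br)cc2)cc1` gives 1860 nM

Compound 2 holds the higher of the two numbers and so shows the weaker inhibition. Compound 3 `Cc1ccc(-c2nn(-c3ccccc3)cc2-c2nc3ccccc3n2S(=O)(=O)c2ccc(C(F)(F)F)cc2)cc1` differs from it by trifluoromethyl in place of bromo on an aromatic carbon in one change, trifluoromethyl in place of bromo on an aromatic carbon. Among the compounds with values here, the only measured step that bears on this is a 6.9-fold higher number from compound 1 to compound 2 (0.84 log units; beyond the scatter) and it replaces a different group, so it does not compare bromo with trifluoromethyl. No step beyond the scatter is therefore expected in this assay for this swap. The expected change is a 1.2-fold lower number from compound 2 to compound 3 (0.07 log units; within the scatter) at most a small one. Compound 3 is estimated at 1600 nM with an expected range of 600 nM to 4500 nM for its value.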

Compound 3, half-maximal inhibitory concentration: 1460 nM
Compound 3: the middle estimate sits 1.1-fold (0.04 log units) above what was measured; low and high end bracket the measured number.
By their numbers in this assay, from the lowest: compound 1; then compounds 3 and 2 (each within the scatter of the next).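

In this assay, trifluoromethyl in place of bromo, para to a large group, gives a 1.3-fold lower number from compound 2 to compound 3 (0.11 log units; within the scatter), so the two groups cannot be told apart at this position. The second para-substituted phenyl also stands apart from 2,5-dimethylphenyl, with a 5.4-fold higher number from compound 1 to compound 3 (0.73 log units; beyond the scatter), so the earlier gap is not peculiar to bromo. Nothing available explains these numbers. Still open, going by these compounds, is whether an amine or a carboxylic acid at this position would read like bromo and trifluoromethyl. Also open, on these data alone, is how each methyl group of the 2,5-dimethylphenyl contributes to the value of compound 1.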